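The source may report more compounds than this note shows. Statements on the series, on what has been measured and on what is new or still open speak of the compounds shown alone.

Values in a functional assay on MDA-MB-231 cells (Homo sapiens) for cytotoxicity, read by sulforhodamine B assay, tested at 10 uM; on this read-out lower numbers stand for less inhibition and higher numbers for more inhibition at the one concentration tested (going by the name of the read-out):

compound 1 `CC(=O)OC[C@H]1O[C@@H](n2cc(-c3cn(Cc4ccccc4)nn3)c(=O)[nH]c2=O)C[C@@H]1OC(C)=O`: 102%
compound 2 `CC(C)(C)c1ccc(Cn2cc(-c3cn([C@H]4C[C@H](O)[C@@H](CO)O4)c(=O)[nH]c3=O)nn2)cc1`: 106%
compound 3 `O=c1[nH]c(=O)n([C@H]2C[C@H](O)[C@@H](CO)O2)cc1-c1cn(Cc2ccccc2)nn1`: 103%

All three numbers lie within the scatter of one another, so no order among compound 1, compound 2 and compound 3 can be read from them. Compound 3 and compound 2 differ in one place only, (tert-butyl in place of hydrogen on an aromatic carbon), and the step in this assay is a number 3 percentage points higher from compound 3 to compound 2 (within the scatter). Compound 1 and compound 3 share the same change of benzyl to 4-(tert-butyl)benzyl on their cores, but the difference between the two cores is not broken down here.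

Compound 4 `CC(=O)OC[C@H]1O[C@@H](n2cc(-c3cn(Cc4ccc(C(C)(C)C)cc4)nn3)c(=O)[nH]c2=O)C[C@@H]1OC(C)=O` is not yet measured. It differs from compound 1 by tert-butyl in place of hydrogen on an aromatic carbon, the same kind of change as from compound 3 to compound 2, at the same place. Because a number 3 percentage points higher from compound 3 to compound 2 (within the scatter) stayed within the scatter, the step of a number 2 percentage points higher from compound 1 to compound 4 (within the scatter) is expected to do the same. Compound 4 is therefore estimated at 104%, between 95% and 112%.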

Compound 4, a percentage reported as inhibition, at one concentration (the size of the read-out at that concentration, not a potency): 105%
Compound 4: middle estimate off by 1 percentage points, on the low side; the measured number falls inside the stated range.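

In this assay, the change of benzyl to 4-(tert-butyl)benzyl gives a number 3 percentage points higher from compound 1 to compound 4 (within the scatter). Set beside the same change on the other core, the new step shows no difference between the two cores: the same change on two cores in this assay, a number 3 percentage points higher (within the scatter) from compound 3 to compound 2 and a number 3 percentage points higher (within the scatter) from compound 1 to compound 4, 0 percentage points apart, within the scatter of two such steps. Going by these compounds alone, both steps lie within the scatter, so this shows only that neither core gives a readable step for this change; it does not show that a step beyond the scatter would carry from one core to the other, and a reading at one concentration says nothing about potency.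

Still open, going by these compounds, is what an amine, a carboxylic acid or a longer chain would do in place of tert-butyl on the six-membered aromatic ring. Also open, on these data alone, is whether any such group would give a step beyond the scatter on either core.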